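An Outer Aryl Ring Change in a Receptor Agonist Series

The compounds below may be only part of what the source reports. "The series", "measured", "known", "first", "only" and "open" are said of these compounds alone.

Compound 2 `N[C@@H](COP(=O)(O)OCCCOC(=O)CCc1ccccc1OCc1cccc(Oc2ccccc2Cl)c1)C(=O)O` and compound 1 `N[C@@H](COP(=O)(O)OCCCOC(=O)CCc1ccccc1OCc1cccc(Cc2ccccc2)c1)C(=O)O` have both been tested in an assay on cells for activation of probable G-protein coupled receptor 34 (Mus musculus), with a stated time of 1 h; a lower number here means a smaller maximal response, a higher number a larger maximal response. Compound 1 gives 0.077, and compound 2 gives 0.069. Among the measured compounds shown here, compound 2 stands lowest of the two numbers, but its only neighbour, compound 1, lies within the usual scatter of it, so the two cannot be ordered. For the measured compounds named here, the one measured step, a number 0.0080 lower from compound 1 to compound 2 (within the scatter), changed the same part of the structure and stayed within the scatter. Compound 3 `CC(C)(C)c1cccc(Oc2cccc(COc3ccccc3CCC(=O)OCCCOP(=O)(O)OC[C@H](N)C(=O)O)c2)c1` has not yet been measured. It differs from compound 2 in one place: 3-(tert-butyl)phenyl in place of 2-chlorophenyl on an oxygen on an aromatic ring. This is the part of the molecule already varied between compound 1 and compound 2 without a step beyond the scatter, so no step beyond the scatter is expected here either. The expected step is a number 0.0010 higher from compound 2 to compound 3 (within the scatter). Compound 3 is therefore estimated at 0.07, with a range from 0.02 to 0.16.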

Compound 3, intrinsic activity: the largest response reached, as a fraction of the reference agonist's: 0.39
The estimate for compound 3 lay 0.32 below the measured number; the whole stated range lies below it.
By their numbers in this assay, from the lowest: compounds 2 and 1 (each within the scatter of the next); then compound 3.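

In this assay, the outer aryl group on this oxygen proved able to change the maximal response, which compound 1 and compound 2 had not shown. Replacing 2-chlorophenyl with 3-(tert-butyl)phenyl gives a number 0.32 higher from compound 2 to compound 3 (beyond the scatter) and so moves the number far beyond what the earlier change did, while replacing benzyl with 3-(tert-butyl)phenoxy gives a number 0.31 higher from compound 1 to compound 3 (beyond the scatter) and shows the same rise against the other earlier compound. Nothing in the available data accounts for this rise.

The compounds shown leave open whether the tert-butyl group itself carries the rise or whether losing the chlorine contributes to it. They also leave open whether an isopropyl group, a trifluoromethyl group or an amine in place of tert-butyl would give a similar maximal response, and whether the rise would persist with the carbon link of the benzyl group.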